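Substituent changes on the shared core: lipophilicity notes

The compounds below may be only part of what the source reports. "The series", "measured", "known", "first", "only" and "open" are said of these compounds alone.

Measured so far in a physicochemical assay for lipophilicity, read by HPLC, in phosphate buffer, measured as chromatographic lipophilicity, at pH 7.4; a higher number here means a more lipophilic compound, a lower number a more polar compound:
compound 1 `Cc1cc(C)cc(NC(=O)COc2cc(C)nc3ccccc23)c1` gives 5.39
compound 2 `Cc1cc(C)cc(NC(=O)COc2cc(C)nc3ccc(F)cc23)c1` gives 5.79
compound 3 `Cc1cc(C)cc(NC(=O)COc2cc(C)nc3ccc(C(F)(F)F)cc23)c1` gives 6.67

Compound 3 stands highest of the three numbers in this assay; the nearest is compound 2 and the furthest compound 1, both steps beyond the scatter. The steps that set this order are a number 0.40 log units higher from compound 1 to compound 2 (beyond the scatter) and a number 1.28 log units higher from compound 1 to compound 3 (beyond the scatter), with a number 0.88 log units higher from compound 2 to compound 3 (beyond the scatter) between the two substituted compounds.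

Compound 4 `CCOc1ccc2nc(C)cc(OCC(=O)Nc3cc(C)cc(C)c3)c2c1` differs from compound 3 in one place: ethoxy in place of trifluoromethyl on an aromatic carbon.

Among the compounds with values here, no measured compound carries an ethoxy group, so the only step that bears directly on this change is the one that put the trifluoromethyl in, a number 1.28 log units higher from compound 1 to compound 3 (beyond the scatter), which was large. Compound 4 undoes that group and puts a different one in its place; the expectation is therefore a step downward in this assay from compound 3, beyond the scatter, but not as far as back to compound 1, since the incoming group is unlikely to leave the number where hydrogen left it. The expected step is a number 0.77 log units lower from compound 3 to compound 4 (beyond the scatter). For compound 4 the estimate in this assay is 5.9, with a range from 5.5 to 6.3.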

Compound 4, distribution coefficient: 5.98
For compound 4 the middle estimate is 0.08 log units below the measured one; measured number inside the range.
By their numbers in this assay, from the lowest: compound 1; then compounds 2 and 4 (each within the scatter of the next); then compound 3.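

At this position in this assay, ethoxy in place of trifluoromethyl gives a number 0.69 log units lower from compound 3 to compound 4 (beyond the scatter) and so shows that a group carrying oxygen on the aromatic carbon does not reach the number held by trifluoromethyl. Ethoxy still stands clear of hydrogen, with a number 0.59 log units higher from compound 1 to compound 4 (beyond the scatter) as the step, while against fluoro the step is a number 0.19 log units higher from compound 2 to compound 4 (within the scatter) and so sets no order between those two groups. The four compounds therefore fall into three levels at this one position: hydrogen, then fluoro and ethoxy together, then trifluoromethyl, with ethoxy bringing one hydrogen-bond acceptor that trifluoromethyl does not have.

Nothing in hand accounts for why the groups fall into these levels.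

As far as these compounds go, whether an amine, a carboxylic acid or a longer alkoxy chain such as butoxy would join one of these levels or fall outside them stays open. The compounds shown also leave open whether the same steps would hold with these groups elsewhere on the shared core, since every change here sits at the one position.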